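Aryl swap on the shared core: compound 2 to compound 3

The compounds below may be only part of what the source reports. "The series", "measured", "known", "first", "only" and "open" are said of these compounds alone.

Measured so far:
compound 1 `Cc1ccnc(-c2ccccc2OCC2=NCCN2)c1` — < 100000 nM
compound 2 `c1cnc(-c2ccccc2OCC2=NCCN2)nc1` — 1260 nM

Going by the values given here, in a functional assay for activation of Alpha-1A adrenergic receptor (Homo sapiens), read by calcium flux (a lower number here means that less compound is needed, a higher number that more compound is needed for the effect), compound 2 gives 1260 nM, the only number in the set. Compound 1 gives < 100000 nM, which is a limit rather than a number, namely (the limit of < 100000 nM in this assay, at which 1 of the 2 values shown sits). Compound 3 `c1csc(-c2ccccc2OCC2=NCCN2)c1` differs from compound 2 by thiophen-2-yl in place of pyrimidin-2-yl on an aromatic carbon. Among the compounds with values here, no step between two measured compounds is available to calibrate this change. The step from compound 2 to compound 3 is expected to be modest, toward less compound needed, and is estimated at a 2.0-fold lower number from compound 2 to compound 3 (0.30 log units; within the scatter). Compound 3 is accordingly expected near 630 nM, with a range from 150 nM to 3000 nM.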

Compound 3, half-maximal effective concentration: 1 nM
For compound 3 the middle estimate is 630-fold (2.80 log units) above the measured one; the measured number lies below the stated range.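

In this assay, thiophen-2-yl in place of pyrimidin-2-yl gives a 1300-fold lower number from compound 2 to compound 3 (3.10 log units; beyond the scatter). The choice of aromatic ring at this place, ortho to a group of 7 heavy atoms, can therefore move the read-out far beyond the scatter, a sensitivity that no earlier comparison could show. Nothing shown gives a reason for the size of this step.

One step cannot separate the contributions of the sulfur, the five-membered ring and the departing nitrogens. Phenyl, furan-2-yl or a chlorothiophene at this place would help to tell these apart.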